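A few compounds are considered here, and "the series" means these few. Any claim that something is new, unique, unknown or untested is made for them only; others in the source may bear on it.

Compound 1 `O=C1O[C@H]([C@@H](O)Cn2cc(CNS(=O)(=O)c3ccc(Cl)cc3F)nn2)C(OCc2ccccc2)=C1OCc1ccccc1`: 21600 nM
Compound 2 `COc1ccccc1-c1cn(C/C=C2\OC(=O)C(OCc3ccccc3)=C2OCc2ccccc2)nn1`: > 100000 nM

Within the data shown here, in a functional assay on HCT-116 cells (Homo sapiens) for antiproliferative activity, read by MTT assay, with a stated time of 72 h (a lower number here means a stronger inhibitor, a higher number a weaker inhibitor), compound 1 gives 21600 nM, the only firm number among the two measured compounds. Compound 2 reaches only a limit of the assay, > 100000 nM, as noted in the limit of > 100000 nM in this assay, at which 1 of the 2 values shown sits. Compound 3 `CCCCc1cn(C[C@H](O)[C@H]2OC(=O)C(OCc3ccccc3)=C2OCc2ccccc2)nn1` has not yet been measured; it differs from compound 1 by propyl in place of ((4-chloro-2-fluorophenyl)sulfonyl)amino on a saturated chain carbon bound to an aromatic carbon. Among the measured compounds shown here, no step between measured compounds is available to calibrate this change, so its size is uncertain; a weakening, or none beyond the scatter, is expected rather than a gain. Compound 3 is estimated at 45000 nM, with a likely range from 15000 nM to 100000 nM. The expected step is a 2.1-fold higher number from compound 1 to compound 3 (0.32 log units; beyond the scatter).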

Compound 3, half-maximal inhibitory concentration: 10400 nM
The estimate for compound 3 lay 4.3-fold (0.64 log units) above the measured number; measured number below the stated range.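

In this assay the swap to propyl from ((4-chloro-2-fluorophenyl)sulfonyl)amino, on a saturated chain carbon bound to an aromatic carbon, gives a 2.1-fold lower number from compound 1 to compound 3 (0.32 log units; beyond the scatter) and so no loss of activity. The aromatic ring and sulfonyl group are therefore not required at this position for activity in these cells. Nothing measured here accounts for the modest gain.

Because the swap removes many atoms at once, the contribution of each part remains unresolved. From the compounds shown here alone, whether a longer chain such as hexyl, or a terminal amine, would strengthen activity further remains open.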